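Fluorine on the aniline ring and kinetic solubility

The compounds below may be only part of what the source reports. "The series", "measured", "known", "first", "only" and "open" are said of these compounds alone.

This account concerns four compounds. Compound 1 has the structure `Fc1ccccc1Nc1nc(-c2ccccc2)cs1`. In a physicochemical assay for solubility, using the shake flask method, measured as kinetic solubility, at pH 7.4 (on this read-out lower numbers stand for lower solubility and higher numbers for higher solubility), compound 1 gives < 1000 nM, which is a limit of the assay and not a number. Compound 2, with the structure `Fc1cccc(-c2csc(Nc3ccccc3F)n2)c1`, differs from compound 1 by fluoro in place of hydrogen on an aromatic carbon. In this assay compound 2 gives < 1000 nM, again a limit rather than a number. The step between them is a step that the two limits leave unreadable from compound 1 to compound 2 due to the limit of < 1000 nM in this assay, at which 2 of the 3 values shown sit. Compound 3 has the structure `O=C(O)c1cccc(-c2cnc(Nc3ccccc3F)o2)c1` and a different core; the difference between the two cores is not broken down here. In this assay, going by the values given here, compound 3 gives 55600 nM, the only number among the three measured values.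

Compound 4, with the structure `O=C(O)c1cccc(-c2cnc(Nc3ccc(F)cc3F)o2)c1`, has not been measured. It differs from compound 3 by fluoro in place of hydrogen on an aromatic carbon. This is the same kind of change as from compound 1 to compound 2, but the place is not the same: in compound 2 the entering fluoro is meta to a large group, whereas in compound 4 it is meta to a fluoro group and para to a large group. The measured step between compound 1 and compound 2 has no readable size, so it offers no number to carry over. Among the compounds with values here, the expectation for compound 4 rests on compound 3 alone, whose value 55600 nM is the one number measured in the set, and on the entering group counting one heavy atom. A step of a 1.9-fold lower number from compound 3 to compound 4 (0.27 log units; within the scatter) is expected from compound 3 to compound 4 in this assay. Compound 4 is thus estimated at 30000 nM, most likely between 12000 nM and 75000 nM.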

Compound 4, solubility: 69000 nM
For compound 4 the middle estimate is 2.3-fold (0.36 log units) below the measured one; the range from low to high includes it.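

In this assay, the new step is a 1.2-fold higher number from compound 3 to compound 4 (0.09 log units; within the scatter), so on the core of compound 3 the fluoro that enters meta to a fluoro group and para to a large group leaves the two compounds indistinguishable on this read-out. The same kind of change on the core of compound 1 cannot be read, because both ends of that step are limits and not numbers: the limit of < 1000 nM in this assay, at which 2 of the 4 values shown sit. The series therefore offers one readable step, on a single core and at a single place, and this shows nothing about whether the result carries over to the other core, where the fluoro also enters at a different place.

The compounds shown leave open whether a chloro, methoxy or amine group entering at the same place on the core of compound 3 would also give a step within the scatter in this assay. They also leave open what a fluoro does on the core of compound 1 when a carboxylic acid, the group that compound 3 and compound 4 carry, or an amine is present on that core, and whether such compounds would give numbers rather than limits.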